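Swapping one pyrazole for another on a urea series

This account rests on a few compounds, and the source may have more. Where it says the series, first, only, none or still open, it means among the compounds named here.

Measured compounds:
- compound 1, `Cc1cc(C)c(NC(=O)N(Cc2ccc(-c3cccs3)cc2)C2CCCCCC2)c(C)c1`, 22 nM
- compound 2, `Cc1cc(C)c(NC(=O)N(Cc2ccc(-c3ccsc3)cc2)C2CCCCCC2)c(C)c1`, 19 nM
- compound 3, `Cc1cc(C)c(NC(=O)N(Cc2ccc(-c3cn[nH]c3)cc2)C2CCCCCC2)c(C)c1`, 270 nM

All three share the same urea core and differ only in the five-membered ring attached to the benzyl group. In an assay on microsomes from intestine for inhibition of acyl-CoA:cholesterol acyltransferase (Oryctolagus cuniculus) (on this read-out higher numbers stand for weaker inhibition and lower numbers for stronger inhibition), compound 3 gives the highest number of the three: a 12-fold higher number from compound 1 to compound 3 (1.09 log units; beyond the scatter) and a 14-fold higher number from compound 2 to compound 3 (1.15 log units; beyond the scatter), while a 1.2-fold lower number from compound 1 to compound 2 (0.06 log units; within the scatter). Compound 4, `Cc1cc(C)c(NC(=O)N(Cc2ccc(-c3ccnn3C)cc2)C2CCCCCC2)c(C)c1`, carries 1-methyl-1H-pyrazol-5-yl in place of 1H-pyrazol-4-yl on an aromatic carbon. Within the data shown here, no measured step covers this exact exchange; the steps that bear on it, from the thiophenes to compound 3, only show that the pyrazol-4-yl ring cost a large amount in this assay. Compound 4 keeps a pyrazole but loses its hydrogen-bond donor and gains a methyl, so the number for compound 4 is expected to move back somewhat toward the thiophenes, estimated as a 2.7-fold lower number from compound 3 to compound 4 (0.43 log units; beyond the scatter). The estimate for compound 4 in this assay is 100 nM, with a range from 30 nM to 350 nM.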

Compound 4, half-maximal inhibitory concentration: 24 nM
Estimate against measurement, compound 4: 4.2-fold (0.62 log units) above, outside the stated range (below it).
By their numbers in this assay, from the lowest: compounds 2, 1 and 4 (each within the scatter of the next); then compound 3.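

In this assay the exchange of rings gives an 11-fold lower number from compound 3 to compound 4 (1.05 log units; beyond the scatter) and so shows that a pyrazole at this position does not by itself carry the loss seen with 1H-pyrazol-4-yl. The two thiophenes offer no real separation from the new ring, with a 1.3-fold higher number from compound 2 to compound 4 (0.10 log units; within the scatter) and a 1.1-fold higher number from compound 1 to compound 4 (0.04 log units; within the scatter) both lying within the scatter, so 1-methyl-1H-pyrazol-5-yl is on a level with thiophen-2-yl and thiophen-3-yl here. No supporting measurement explains the difference between the two pyrazoles.

Compound 4 differs from compound 3 in its added methyl, its missing hydrogen-bond donor and the point where the ring is attached, so 1-methyl-1H-pyrazol-4-yl would be needed to separate these changes. As far as these compounds go, how a pyridine ring or a dimethylamino group would behave at this position also remains open.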